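The source may hold more compounds than are shown below. What is called first, only, known or untested is meant among the compounds shown, and "the series" means these compounds.

Two close relatives of a shared core have been tested so far. Compound 1, `CN(C(=O)c1ccc(F)cc1)c1ccc2[nH]c(-c3n[nH]c4ccccc34)cc2n1`, carries a 4-fluorophenyl group on its carbonyl carbon, while compound 2, `CN(C(=O)c1ccccc1)c1ccc2[nH]c(-c3n[nH]c4cc(Cl)ccc34)cc2n1`, carries a plain phenyl there and a chlorine on a different ring. In a functional assay on KB cells (Homo sapiens) for antiproliferative activity, read by MTT assay, with a stated time of 72 h (a lower number here means a stronger inhibitor, a higher number a weaker inhibitor), compound 1 gives 7220 nM, and in this assay compound 2 gives 5590 nM. For the measured compounds named here, these two numbers sit within the usual scatter of each other, so neither compound can be called the stronger or the weaker of the pair; compound 1 simply is one of two, and nothing separates it from its only neighbour.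

Compound 3, `CN(C(=O)Nc1ccccc1)c1ccc2[nH]c(-c3n[nH]c4ccccc34)cc2n1`, is not yet measured. It differs from compound 1 in one place: anilino in place of 4-fluorophenyl on a carbonyl carbon. Described one bond further out, a (4-fluorophenyl)carbonyl becomes a phenylcarbamoyl. Going by the values given here, no measured pair shows what this exchange does on this core, so the expectation rests on the two numbers alone. A step from compound 1 to compound 3 of about a 1.0-fold lower number from compound 1 to compound 3 (0.01 log units; within the scatter) is expected, that is, nothing clearly beyond the scatter in either direction. Compound 3 is therefore estimated at 7000 nM, within a range from 2500 nM to 20000 nM.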

Compound 3, half-maximal inhibitory concentration: 32 nM
Estimate against measurement, compound 3: 220-fold (2.34 log units) above; measured number below the stated range.
By their numbers in this assay, from the lowest: compound 3; then compounds 2 and 1 (each within the scatter of the next).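

In this assay, this place on the carbonyl carbon proves highly sensitive: putting anilino in place of 4-fluorophenyl gives a 230-fold lower number from compound 1 to compound 3 (2.35 log units; beyond the scatter), a large step that the earlier pair could not reveal, since those compounds differ in more than one place. The exchange keeps the heavy-atom count and the six-membered carbon ring, so a large change in activity here does not require a larger group; what differs is that a fluorine leaves, while a nitrogen bearing a hydrogen-bond donor enters and links the ring to the carbonyl. No measurement shown here explains why the step is so large.

The exchange makes two alterations at once, so these compounds cannot separate the effect of the added nitrogen from that of the lost fluorine; 4-fluoroanilino on the same carbonyl carbon would be one way to pull them apart. On these data alone, it also remains open whether the aromatic ring is needed on this nitrogen, or whether a smaller methylamino or a phenoxy group, with oxygen in place of that nitrogen, would behave like anilino.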